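The source may hold more compounds than are shown below. What is called first, only, known or untested is meant among the compounds shown, and "the series" means these compounds.

Compound 3 `CC(C)C[C@H](N)CN(C(=O)[C@@H]1C[C@H]1c1ccccc1)c1ccc(C2=CCCCCC2)cc1` gives 2100 nM in a functional assay for agonist activity at G protein-coupled receptor 88 (Homo sapiens), read by HTRF and cAMP accumulation (on this read-out higher numbers stand for an effect only at larger amounts of compound and lower numbers for an effect already at smaller amounts), the highest of the three numbers available. Compound 1 `CC[C@H](C)[C@H](N)CN(C(=O)[C@@H]1C[C@H]1c1ccc(F)cc1F)c1ccc(-c2ccccc2)cc1` gives 1300 nM, and this gap lies within the usual scatter, while compound 2 `CC[C@H](C)[C@H](N)CN(C(=O)[C@@H]1C[C@H]1c1ccccn1)c1ccc(-c2ccccc2)cc1` gives 130 nM, a gap that lies beyond it. Compound 4 `COc1ccccc1-c1ccc(N(C[C@@H](N)CC(C)C)C(=O)[C@@H]2C[C@H]2c2ccccc2)cc1` differs from compound 3 by 2-methoxyphenyl in place of cyclohept-1-en-1-yl on an aromatic carbon. Among the measured compounds shown here, the only measured step, a 10-fold lower number from compound 1 to compound 2 (1.00 log units; beyond the scatter), exchanges a group on a saturated ring carbon, a different place, so it does not bear directly on this change. For the measured compounds named here, no measured pair shows what swapping the group on this aromatic carbon does. Compound 4 is therefore expected, with little certainty, to give 1200 nM, within 300 nM to 5000 nM. The expected step is a 1.8-fold lower number from compound 3 to compound 4 (0.24 log units; within the scatter).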

Compound 4, half-maximal effective concentration: 3200 nM
The estimate for compound 4 lay 2.7-fold (0.43 log units) below the measured number; the measured number falls inside the stated range.
By their numbers in this assay, from the lowest: compound 2; then compounds 1, 3 and 4 (each within the scatter of the next, the first and the last beyond it).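

In this assay, 2-methoxyphenyl in place of cyclohept-1-en-1-yl on this aromatic carbon gives a 1.5-fold higher number from compound 3 to compound 4 (0.18 log units; within the scatter) and so stays within the scatter. This first measured pair at this position shows that a seven-membered non-aromatic carbon ring and a six-membered aromatic ring bearing a methoxy group cannot be told apart on this read-out. Nothing available explains this result.

Still open, going by these compounds, is whether an amine or a carboxylic acid on this carbon would move the number beyond the scatter. Also open, on these data alone, is whether 2-methoxyphenyl would give a similar result on the core of compound 2.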